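Swapping a Selenium-Bearing Ester for an Aminoethoxy Chain

A few compounds are considered here, and "the series" means these few. Any claim that something is new, unique, unknown or untested is made for them only; others in the source may bear on it.

Compound 1 `COc1ccc(N(C)c2nc(C)nc3ccccc23)cc1C(=O)OCC[Se]C#N` was tested in a functional assay on A549 cells (Homo sapiens) for inhibition, read by MTT assay, with a stated time of 48 h (on this read-out higher numbers stand for weaker inhibition and lower numbers for stronger inhibition), where compound 1 gives 353 nM. This is the higher of the two numbers in hand. The other measured compound, compound 2 `Cc1nc(N(C)c2ccc([Se]C#N)c(F)c2)c2ccccc2n1`, gives 4 nM in this assay, a gap that lies well beyond the scatter of repeated measurements. Compound 3 `COc1ccc(N(C)c2nc(C)nc3ccccc23)cc1OCCN` has not yet been measured. It differs from compound 1 in one place: a group of 4 heavy atoms (2 carbon, 1 nitrogen, 1 oxygen; no ring) in place of a group of 8 heavy atoms (4 carbon, 1 nitrogen, 2 oxygen, 1 selenium; no ring), on an aromatic carbon. The group that leaves is the one carrying the selenium atom, and the 2-aminoethoxy group that enters carries none. Among the measured compounds shown here, no step between measured compounds shows this change, so the expectation rests on the standing of compound 1 alone. In this assay a moderate rise toward weaker inhibition is expected, a 5.7-fold higher number from compound 1 to compound 3 (0.75 log units; beyond the scatter). Compound 3 is thus estimated at 2000 nM, with a range from 400 nM to 10000 nM.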

Compound 3, half-maximal inhibitory concentration: 122 nM
For compound 3 the middle estimate is 16-fold (1.21 log units) above the measured one; the whole stated range lies above it.
By their numbers in this assay, from the lowest: compound 2; then compound 3; then compound 1.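

In this assay the selenium-bearing ester proves not to be required for inhibition at this position: putting 2-aminoethoxy in its place gives a 2.9-fold lower number from compound 1 to compound 3 (0.46 log units; beyond the scatter), a modest step toward stronger inhibition. This aromatic carbon, ortho to a methoxy group, therefore accepts a smaller chain that carries no selenium and ends in an amine without any loss of inhibition on these cells. No measurement in hand explains why the number falls.

The change removes the ester and the selenium and adds the amine all at once, so the contribution of each part remains unresolved. From the compounds shown here alone, it also remains open how a longer chain such as 3-aminopropoxy, or a 2-hydroxyethoxy group with an oxygen in place of the amine nitrogen, would behave here.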